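A few compounds are considered here, and "the series" means these few. Any claim that something is new, unique, unknown or untested is made for them only; others in the source may bear on it.

The series shares the core seen in compound 1 `Cc1cccc(C(=O)NN(C(=O)c2ccccc2Cl)C(C)(C)C)c1` and compound 2 `CC(C)(C)N(NC(=O)c1ccc(Cl)cc1)C(=O)c1ccccc1Cl`. In an assay on cells for agonist activity at ecdysone receptor (Bombyx mori), read by a luciferase reporter, with a stated time of 24 h (a lower number here means that less compound is needed, a higher number that more compound is needed for the effect), compound 1 gives 603 nM; in this assay compound 2 gives 115 nM. Among the measured compounds shown here, the single step measured so far, a 5.2-fold lower number from compound 1 to compound 2 (0.72 log units; beyond the scatter), exchanges one aryl group on a carbonyl carbon for another. For the measured compounds named here, on the numbers in hand compound 2 stands lowest of the two, with compound 1 as its only neighbour, at a higher number beyond the scatter.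

Compound 3 `CC(C)(C)N(NC(=O)c1ccc(I)cc1)C(=O)c1ccccc1Cl` is not yet measured. It differs from compound 2 by iodo in place of chloro on an aromatic carbon, on an aromatic carbon of a six-membered aromatic ring of carbon only, para to a large group. Going by the values given here, no measured step in this assay exchanges one halogen for another; the one step in hand replaces a whole aryl group and does not bear on this change. With nothing in the data to set a direction, the expected step of a 1.0-fold lower number from compound 2 to compound 3 (0.02 log units; within the scatter) is none beyond the scatter. For compound 3 in this assay the estimate is 110 nM, within the range 40 nM to 300 nM.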

Compound 3, half-maximal effective concentration: 7.59 nM
Compound 3: the middle estimate sits 14-fold (1.16 log units) above what was measured, outside the stated range (below it).
By their numbers in this assay, from the lowest: compound 3; then compound 2; then compound 1.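

Working notes on the halogen position: in this assay, iodo in place of chloro on this aromatic carbon, para to a large group, gives a 15-fold lower number from compound 2 to compound 3 (1.18 log units; beyond the scatter) and is graded large, whereas the exchange of a whole aryl group in a 5.2-fold lower number from compound 1 to compound 2 (0.72 log units; beyond the scatter) is graded modest. The position is therefore sensitive to the identity of a single atom, even though the computed counts of rings, hydrogen-bond donors, hydrogen-bond acceptors and net charge stay the same for the two groups. Against the 3-methylphenyl of the first compound, the 4-iodophenyl group gives a 79-fold lower number from compound 1 to compound 3 (1.90 log units; beyond the scatter) and is also graded large, which places compound 3 lowest of the three, with both of its steps beyond the scatter. Nothing available beyond these potency values bears on this result.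

The compounds shown leave open where bromo, fluoro, trifluoromethyl, methoxy, an amine or a carboxylic acid would fall on the same aromatic carbon, so two halogens do not yet define a trend. As far as these compounds go, it also remains open whether iodo in place of chloro would give a comparable step if the chloro on the other aryl group of the shared core or the tert-butyl group were exchanged.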